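The source may report more compounds than this note shows. Statements on the series, on what has been measured and on what is new or still open speak of the compounds shown alone.

Compound 1, `CC(=O)Nc1nc(-c2cccc(NS(=O)(=O)c3ccc(Br)cc3)c2)cs1`, gives 19.7% in a functional assay on A-375 cells (Homo sapiens) for antiproliferative activity, read by trypan blue exclusion, with a stated time of 48 h, tested at 5 uM; a higher number here means a weaker effect of the compound at the concentration tested, a lower number a stronger effect.
Compound 2, `CC(=O)Nc1nc(-c2cccc(NS(=O)(=O)c3ccc(C#CC4CCCCC4)cc3)c2)cs1`, gives 1.2% in this assay.
Compound 3, `CCCCCCCCC#Cc1ccc(S(=O)(=O)Nc2cccc(-c3csc(NC(C)=O)n3)c2)cc1`, gives 8.9% in this assay.

Among these three numbers compound 3 stands second highest in this assay. Its nearest neighbour is reached by the step of a number 7.7 percentage points higher from compound 2 to compound 3 (within the scatter); its furthest by the step of a number 10.8 percentage points lower from compound 1 to compound 3 (beyond the scatter).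

Compound 4, `CC(=O)Nc1nc(-c2cccc(NS(=O)(=O)c3ccc(C#CCCc4ccccc4)cc3)c2)cs1`, differs from compound 3 in one place: phenyl in place of hexyl on a saturated chain carbon, two bonds along the chain from a triple-bonded carbon. Among the compounds with values here, the only measured step that bears on exchanging a chain for a ring out on the alkyne is a number 7.7 percentage points higher from compound 2 to compound 3 (within the scatter), which stayed within the scatter. Compound 4 is therefore expected to show no step beyond the scatter in this assay, a number 2.9 percentage points lower from compound 3 to compound 4 (within the scatter). Compound 4 is estimated at 6%, within 0% to 18%.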

Compound 4, a percentage reported as activity, at one concentration (the size of the read-out at that concentration, not a potency): 4.2%
The estimate for compound 4 lay 1.8 percentage points above the measured number, and the stated range covers the measured number.
By their numbers in this assay, from the lowest: compounds 2, 4 and 3 (each within the scatter of the next); then compound 1.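

Placing an aromatic ring at the end of the alkyne chain, with phenyl in place of hexyl, gave no step beyond the scatter in this assay (a number 4.7 percentage points lower from compound 3 to compound 4 (within the scatter)), and neither did phenethyl in place of cyclohexyl (a number 3 percentage points higher from compound 2 to compound 4 (within the scatter)). The 4-phenylbut-1-yn-1-yl group also stood apart from bromo (a number 15.5 percentage points lower from compound 1 to compound 4 (beyond the scatter)), so the aromatic, saturated-ring and straight-chain alkynes all read alike here. Nothing available explains this shared reading.

Going by these compounds, it remains open whether an amine or a carboxylic acid at the end of the alkyne chain would keep this reading. On these data alone, a shorter chain is equally open.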